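The source may hold more compounds than are shown below. What is called first, only, known or untested is meant among the compounds shown, and "the series" means these compounds.

Of the compounds shown here, three sharing one core have so far been tested in an assay on a protein complex (Cavia porcellus) with sulfonylurea receptors; K-ATP channels (Homo sapiens) as the target; on this read-out higher numbers stand for weaker inhibition and lower numbers for stronger inhibition. Compound 1 `CCC(C)N(C(C)CC)S(=O)(=O)c1ccc(NC(=O)C(C)(O)C(F)(F)F)cc1` carries a bis(sec-butyl)amino group on the sulfonyl sulfur. In this assay compound 1 returns only a limit, > 30000 nM. Compound 2 `CC(C)CN(CC(C)C)S(=O)(=O)c1ccc(NC(=O)C(C)(O)C(F)(F)F)cc1` carries a diisobutylamino group instead. For compound 2 this assay again reports only a limit, > 30000 nM. Compound 3 `CCCN(CCC)S(=O)(=O)c1ccc(NC(=O)C(C)(O)C(F)(F)F)cc1` carries the smaller dipropylamino group, and in this assay compound 3 gives 6440 nM, a real number. The step that the two limits leave unreadable from compound 1 to compound 2 cannot be read, since both compounds sit at the same limit (the limit of > 30000 nM in this assay, at which 2 of the 3 values shown sit). The steps of an at least 4.6-fold lower number from compound 1 to compound 3 (0.66 log units; beyond the scatter) and an at least 4.6-fold lower number from compound 2 to compound 3 (0.66 log units; beyond the scatter) both show that the shorter chains go with a stronger inhibition.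

Compound 4 `CC(O)(C(=O)Nc1ccc(S(=O)(=O)N2CCSCC2)cc1)C(F)(F)F` is not yet measured. It differs from compound 2 in one place: thiomorpholin-4-yl in place of diisobutylamino on a sulfonyl sulfur. As in the step to compound 3, the group on the sulfonyl sulfur becomes smaller, here closing into a ring. Taking the step of an at least 4.6-fold lower number from compound 2 to compound 3 (0.66 log units; beyond the scatter) as the guide, compound 4 is expected to move away from the limit, with the step of an at least 3.7-fold lower number from compound 2 to compound 4 (0.57 log units; beyond the scatter). The estimate for compound 4 in this assay is therefore 8000 nM, with a range from 2500 nM to 30000 nM.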

Compound 4, half-maximal inhibitory concentration: 4580 nM
Estimate against measurement, compound 4: 1.7-fold (0.24 log units) above; the measured number falls inside the stated range.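

In this assay the closed thiomorpholin-4-yl ring on the sulfonyl sulfur cannot be told apart from the open dipropylamino group, with a 1.4-fold lower number from compound 3 to compound 4 (0.15 log units; within the scatter) and therefore no order between the two. Set against the two larger branched groups, the same ring gives an at least 6.5-fold lower number from compound 2 to compound 4 (0.81 log units; beyond the scatter) and an at least 6.5-fold lower number from compound 1 to compound 4 (0.81 log units; beyond the scatter) so the lower numbers seen so far are not tied to open straight chains, and a ring holding a sulfur atom and a hydrogen-bond acceptor also reaches them. Both of these steps are only minimum sizes because compound 1 and compound 2 rest on a limit of the assay and not on a number: the limit of > 30000 nM in this assay, at which 2 of the 4 values shown sit.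

The compounds shown leave open whether the sulfur of the ring plays any part, which a morpholin-4-yl ring, with oxygen in its place, or a piperidin-1-yl ring, with carbon there, could test. They also leave open whether the number falls further with a still smaller group on the sulfonyl sulfur, such as dimethylamino.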